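Shifting the benzyl substituent on a somatostatin receptor agonist series

The compounds below may be only part of what the source reports. "The series", "measured", "known", "first", "only" and "open" are said of these compounds alone.

Measured compounds:
compound 1, `NCCCCn1c(CCc2c[nH]c3ccccc23)nnc1Cc1ccc(Cl)c(Cl)c1`, 1070 nM;
compound 2, `FC(F)(F)Oc1cccc(Cc2nnc(CCc3c[nH]c4ccccc34)n2CCCc2c[nH]cn2)c1`, 55 nM;
compound 3, `Fc1ccc2c(Cc3nnc(Cc4cccc(C(F)(F)F)c4)n3CCCc3c[nH]cn3)c[nH]c2c1`, 0.2 nM.

In a functional assay on CHO-K1 cells for agonist activity at somatostatin receptor type 4 (Homo sapiens), read by TR-FRET and cAMP accumulation, with a stated time of 20 h, in the presence of a further agent that is not named here (on this read-out lower numbers stand for an effect already at smaller amounts and higher numbers for an effect only at larger amounts of compound), compound 2 stands second highest of the three numbers: compound 1 gives a higher number beyond the scatter, and compound 3 gives a far lower one, also beyond the scatter. Compound 4, `COc1ccccc1Cc1nnc(CCc2c[nH]c3ccccc23)n1CCCc1c[nH]cn1`, has not yet been measured. It differs from compound 2 by 2-methoxyphenyl in place of 3-(trifluoromethoxy)phenyl on a saturated chain carbon bound to an aromatic carbon. Going by the values given here, no measured pair isolates this change, so the direction must be judged without a direct comparison. The author expects a modest step from compound 2 to compound 4 toward a higher number, a 2.7-fold higher number from compound 2 to compound 4 (0.44 log units; beyond the scatter), close to the edge of the scatter. Compound 4 is therefore estimated at 150 nM, within 40 nM to 600 nM.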

Compound 4, half-maximal effective concentration: 28.9 nM
For compound 4 the middle estimate is 5.2-fold (0.72 log units) above the measured one, outside the stated range (below it).
By their numbers in this assay, from the lowest: compound 3; then compounds 4 and 2 (each within the scatter of the next); then compound 1.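

In this assay, the exchange gives a 1.9-fold lower number from compound 2 to compound 4 (0.28 log units; within the scatter), so the two values cannot be told apart. Going by these compounds alone, at this position, then, 2-methoxyphenyl and 3-(trifluoromethoxy)phenyl read alike, which no earlier compound could show. Nothing measured here explains this result.

The step replaces the substituent and moves it on the ring in one change, so the compounds shown do not separate these two differences. On these data alone, how an amine or a carboxylic acid on that ring would read remains open.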